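A few compounds are considered here, and "the series" means these few. Any claim that something is new, unique, unknown or untested is made for them only; others in the source may bear on it.

Measured in an ADME assay on HEK293 cells (Homo sapiens) for cytotoxicity, read by MTT assay, with a stated time of 72 h; on this read-out higher numbers stand for weaker inhibition and lower numbers for stronger inhibition:
compound 1 `COc1ccc(C(=O)N2CCN(CC(=O)N3CCN(CCCc4c[nH]c5ccccc45)CC3)CC2)cc1`: 156000 nM
compound 2 `COc1ccc(C(=O)N2CCN(CC(=O)N3CCN(CCCc4c[nH]c5ccc(F)cc45)CC3)CC2)cc1`: 141000 nM

Compound 2 holds the lower of the two numbers, with compound 1 nearest; the step of a 1.1-fold lower number from compound 1 to compound 2 (0.04 log units; within the scatter) is within the scatter, so the two read as alike. Compound 3 `O=C(CN1CCN(C(=O)c2cccc(Br)c2)CC1)N1CCN(CCCc2c[nH]c3ccc(F)cc23)CC1` differs from compound 2 by 3-bromophenyl in place of 4-methoxyphenyl on a carbonyl carbon. Going by the values given here, no measured step touches the group on the carbonyl carbon; the only measured step concerns a fluoro elsewhere and sits within the scatter, so it offers no direction for this change. Compound 3 is expected to give about 120000 nM in this assay, between 50000 nM and 260000 nM. The expected step is a 1.2-fold lower number from compound 2 to compound 3 (0.07 log units; within the scatter), not beyond the scatter.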

Compound 3, half-maximal inhibitory concentration: 40600 nM
Beside the measured number, compound 3's estimate is 3.0-fold (0.47 log units) above it, and the stated range ends above it.
By their numbers in this assay, from the lowest: compound 3; then compounds 2 and 1 (each within the scatter of the next).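

In this assay, the group on the carbonyl carbon shifts the number where the fluoro step did not: 3-bromophenyl in place of 4-methoxyphenyl gives a 3.5-fold lower number from compound 2 to compound 3 (0.54 log units; beyond the scatter) as a modest change. Going by these compounds alone, this is the first sign that this position bears on the read-out. No measurement at hand explains the step.

The change alters both the substituent and its ring position, so the contributions of each remain unseparated. A 4-bromophenyl or 3-methoxyphenyl group on the same carbonyl carbon would separate them.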